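The compounds below may be only part of what the source reports. "The series", "measured", "known", "first", "only" and "open" are said of these compounds alone.

Measured compounds in an ADME assay on HepG2 cells (Homo sapiens) for cytotoxicity, read by resazurin assay, with a stated time of 24 h; on this read-out higher numbers stand for lower toxicity in this test and lower numbers for higher toxicity in this test:
- compound 1, `COc1cc(O)c(C(=O)O)c(C=Cc2ccc3ccccc3c2)c1`, gives 79000 nM
- compound 2, `Cc1cc(O)c(C(=O)O)c(CCc2ccc3ccccc3c2)c1`, gives 38000 nM
- compound 3, `Cc1cc(O)c(C(=O)O)c(C=Cc2ccc3ccccc3c2)c1`, gives 30000 nM

Compounds 2 and 3 share the same substitution pattern but differ in the linker to the naphthyl part; the difference between the two cores is not broken down here, and their values lie within the scatter of one another. Among the measured compounds shown here, the one counted change is methoxy in place of methyl on an aromatic carbon, which gave a 2.6-fold higher number from compound 3 to compound 1 (0.42 log units; beyond the scatter) in this assay, a modest rise that lies beyond the scatter.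

Compound 4, `COc1cc(O)c(C(=O)O)c(CCc2ccc3ccccc3c2)c1`, is not yet measured. It relates to compound 2 as compound 1 relates to compound 3: methoxy in place of methyl on an aromatic carbon, a change at the same place and of the same kind. For the measured compounds named here, on the core of compound 2 the step from compound 2 to compound 4 is expected to be a 2.4-fold higher number from compound 2 to compound 4 (0.37 log units; beyond the scatter) in this assay, resting on the single earlier step of a 2.6-fold higher number from compound 3 to compound 1 (0.42 log units; beyond the scatter) and on compound 2 at 38000 nM as the starting point. Compound 4 is thus estimated at 90000 nM, within 45000 nM to 180000 nM, in this assay.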

Compound 4, half-maximal cytotoxic concentration: 71000 nM
Compound 4: the middle estimate sits 1.3-fold (0.10 log units) above what was measured; measured number inside the range.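

Within this assay methoxy in place of methyl on an aromatic carbon now gives a 1.9-fold higher number from compound 2 to compound 4 (0.27 log units; within the scatter) on a second core, and this step can be read beside the earlier one. The two steps agree within the scatter, so no difference between the cores can be seen for this change: the same change on two cores in this assay, a 2.6-fold higher number (0.42 log units; beyond the scatter) from compound 3 to compound 1 and a 1.9-fold higher number (0.27 log units; within the scatter) from compound 2 to compound 4, 1.4-fold (0.15 log units) apart, within the scatter of two such steps.
Among the compounds shown here, this rests on only two matched pairs. The new step alone lies within the scatter. It does not establish an effect of the change on that core by itself, nor does it show that the change would carry to any further core.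

Open, as far as these compounds go, is whether the same pattern would hold for an ethoxy group, a chlorine atom or an amine on the same aromatic carbon. Also open, from the compounds shown here alone, is how the change would behave with a longer chain to the naphthyl part, or with an amide in place of the carboxy group.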